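The source may hold more compounds than are shown below. What is called first, only, known or untested is meant among the compounds shown, and "the series" means these compounds.

In a functional assay on HepG2 cells (Homo sapiens) for inhibition, read by MTT assay, with a stated time of 72 h (on this read-out lower numbers stand for stronger inhibition and higher numbers for weaker inhibition), compound 3 `COc1ccc(-c2nnc(SCCCN3CCN(c4nc5ccccc5s4)CC3)o2)cc1` gives 134000 nM, within the scatter of compound 2 `Clc1ccc(-c2nnc(SCCCN3CCN(c4nc5ccccc5o4)CC3)o2)cc1` at 121000 nM, while compound 1 `COc1ccc(-c2nnc(SCCCN3CCN(c4nc5ccccc5o4)CC3)o2)cc1` gives 66100 nM. Compound 4 `Fc1ccc(-c2nnc(SCCCN3CCN(c4nc5ccccc5s4)CC3)o2)cc1` differs from compound 3 at one place, on an aromatic carbon para to a large group: fluoro in place of methoxy on an aromatic carbon. The nearest measured change, chloro in place of methoxy, was a 1.8-fold higher number from compound 1 to compound 2 (0.26 log units; within the scatter). The other measured change, a 2.0-fold higher number from compound 1 to compound 3 (0.31 log units; beyond the scatter), concerns a different part of the molecule and mainly sets the starting point. Within the data shown here, no fluoro compound has a measured value yet. In this assay the expected step, a 1.1-fold higher number from compound 3 to compound 4 (0.05 log units; within the scatter), is therefore small, with a slightly higher number at most. For compound 4 the estimated value is 150000 nM, with an expected range from 70000 nM to 310000 nM.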

Compound 4, half-maximal inhibitory concentration: 234000 nM
The estimate for compound 4 lay 1.6-fold (0.19 log units) below the measured number; measured number inside the range.
By their numbers in this assay, from the lowest: compounds 1, 2, 3 and 4 (each within the scatter of the next, the first and the last beyond it).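

In this assay, fluoro in place of methoxy on an aromatic carbon para to a large group gives a 1.7-fold higher number from compound 3 to compound 4 (0.24 log units; within the scatter). Among these compounds, this is the first replacement of methoxy at this position tested with the 1,3-benzothiazol-2-yl group, and, as with chloro and the 1,3-benzoxazol-2-yl group in a 1.8-fold higher number from compound 1 to compound 2 (0.26 log units; within the scatter), the step stays within the scatter. Nothing available here explains this result. Still open, from the compounds shown here alone, is whether an amine or a carboxylic acid at this position would give a step beyond the scatter, and whether fluoro behaves the same with the 1,3-benzoxazol-2-yl group.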